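Removal of the aroyl group from the thioether side chain

The source may report more compounds than this note shows. Statements on the series, on what has been measured and on what is new or still open speak of the compounds shown alone.

Compound 1 `CCc1nnc(SCC(=O)c2ccccc2)n1N1C(=O)c2ccccc2C1=O` in a functional assay on PC-3M cells (Homo sapiens) for cytotoxicity, read by MTT assay, with a stated time of 48 h; a higher number here means a weaker inhibitor, a lower number a stronger inhibitor: compound 1 gives > 200000 nM, a limit of this assay.
Compound 2 `CCc1nnc(SCC(=O)c2ccc(C)cc2)n1N1C(=O)c2ccccc2C1=O` in this assay : compound 2 gives > 200000 nM, likewise a limit.

Compound 2 stands at the limit of this assay, and the step that the two limits leave unreadable from compound 1 to compound 2 cannot be read, as both values are limits (the limit of > 200000 nM in this assay, at which 2 of the 2 values shown sit). The next change, (hydrogen in place of (4-methylphenyl)carbonyl on a saturated chain carbon bound to a sulfur), gives compound 3 `CCc1nnc(SC)n1N1C(=O)c2ccccc2C1=O`, the compound with the bare methylthio chain on the shared core. Going by the values given here, no measured step bears on this change: the only step recorded, from compound 1 to compound 2, is unreadable, and both compounds sit at the limit. The expectation for compound 3 is therefore only that it stays near the limit, with the step of a number no higher from compound 2 to compound 3 (the limit leaves the size open) estimated as none beyond the scatter. Compound 3 is expected to give 200000 nM in this assay, within 50000 nM to 1000000 nM.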

Compound 3, half-maximal inhibitory concentration: > 200000 nM
Compound 3: only a limit was reported; the forecaster's own chance of this, stated with the estimate: 85%; the middle value sits exactly at the limit.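

Compound 1, compound 2 and compound 3 all give only a limit, so no step among them can be read in this assay: the limit of > 200000 nM in this assay, at which 3 of the 3 values shown sit.

The compounds shown leave open whether any of these side-chain changes on the shared core alters cytotoxicity.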